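The source may report more compounds than this note shows. Statements on the series, on what has been measured and on what is new or still open speak of the compounds shown alone.

Compound 1 `S=c1oc(-c2ccc3c(c2)OCCO3)nn1CN1CCN(c2ccccc2)CC1`: > 50000 nM
Compound 2 `S=c1oc(-c2ccc3c(c2)OCCO3)nn1CN1CCN(c2ccccc2Cl)CC1`: > 50000 nM

In a functional assay on SW 1116 cells (Homo sapiens) for antiproliferative activity, read by MTT assay, with a stated time of 48 h (on this read-out higher numbers stand for weaker inhibition and lower numbers for stronger inhibition), compound 1 gives only a limit of the assay, > 50000 nM. Compound 2 also gives only a limit, > 50000 nM. Going by the values given here, the one measured step, a step that the two limits leave unreadable from compound 1 to compound 2, is therefore not readable in size, and the whole of the measured data rests on (the limit of > 50000 nM in this assay, at which 2 of the 2 values shown sit). So compound 1 stands at the limit of the assay, with no number of its own to place it.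

Compound 3 `S=c1oc(-c2ccc3c(c2)OCCO3)nn1CN1CCN(c2ccccn2)CC1` has not yet been measured. It differs from compound 1 by pyridin-2-yl in place of phenyl on an amine nitrogen in a ring. Among the compounds with values here, no measured step involves a pyridin-2-yl group, and the only step available, from a phenyl to a chloro-bearing phenyl on the same amine nitrogen, is unreadable between its two limits. There is thus nothing in the data that points to a step in either direction beyond the scatter. Compound 3 is therefore expected to sit at the limit as well, with a number no higher from compound 1 to compound 3 (the limit leaves the size open) expected to be unreadable, and its estimated value is 50000 nM, between 15000 nM and 200000 nM.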

Compound 3, half-maximal inhibitory concentration: 9490 nM
Compound 3: middle estimate off by 5.3-fold (0.72 log units), on the high side; measured number below the stated range.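

Going by these compounds alone, this is the first change on the amine nitrogen in a ring that can be read in this assay: pyridin-2-yl in place of phenyl gives an at least 5.2-fold lower number from compound 1 to compound 3 (0.72 log units; beyond the scatter), and pyridin-2-yl in place of 2-chlorophenyl gives an at least 5.2-fold lower number from compound 2 to compound 3 (0.72 log units; beyond the scatter). Compound 3 thus gives the series its first value that is not a limit, which shows that the group on this nitrogen can bring the read-out clear of that limit, even though the entering and leaving groups have the same count of heavy atoms and differ in the aromatic ring by one nitrogen in place of one carbon. Both steps start from a limit, so they give only the smallest possible size and not a measured gap: the limit of > 50000 nM in this assay, at which 2 of the 3 values shown sit.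

The compounds shown leave open whether the lower number depends on where the ring nitrogen stands, as pyridin-3-yl or pyridin-4-yl groups would test, or whether a pyrimidin-2-yl group would lower it further. They also leave open whether a methyl or methoxy group on the pyridin-2-yl ring would keep the lower number, and whether the same change would hold on other cell lines.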